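A Benzyl Ester at the Edge of a Limit

The compounds below may be only part of what the source reports. "The series", "measured", "known", "first", "only" and "open" are said of these compounds alone.

In an ADME assay on BJ cells (Homo sapiens) for cytotoxicity, with a stated time of 72 h (a lower number here means that less compound is needed, a higher number that more compound is needed for the effect), compound 3 (`CCOC(=O)/C=C/c1cc(/C=C/[C@](C)(/C=C/c2ccc(OC)cc2)CCC=C(C)C)ccc1O`) gives > 36600 nM as a limit of the assay, not a number. Compound 1 (`C=C[C@@](C)(/C=C/c1ccc(O)cc1)CCC(O)C(C)(C)O`) gives > 36600 nM as a limit too. Compound 2 (`C=C[C@@](C)(/C=C/c1ccc(O)c(/C=C/C(=O)OCC)c1)CCC=C(C)C`) likewise gives > 36600 nM as a limit. The set therefore rests on the limit of > 36600 nM in this assay, at which 3 of the 3 values shown sit, and offers no number. For the measured compounds named here, the only measured step is a step that the two limits leave unreadable from compound 2 to compound 3 and it has no readable size to carry over. Compound 4 (`COc1ccc(/C=C/[C@@](C)(/C=C/c2ccc(O)c(/C=C/C(=O)OCc3ccccc3)c2)CCC=C(C)C)cc1`) differs by phenyl in place of methyl on a saturated chain carbon bound to an oxygen next to a carbonyl group and so carries benzyloxycarbonyl in place of ethoxycarbonyl. No step beyond the scatter is expected, and the expected change is a number no higher from compound 3 to compound 4 (the limit leaves the size open) in this assay with no direction. The estimate for compound 4 is 36600 nM within an expected range of 15000 nM to 60000 nM and most likely reported as a limit again.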

Compound 4, half-maximal effective concentration: > 36600 nM
Compound 4: a limit, no number (the forecaster's own chance of this, stated with the estimate: 85%); the middle value sits exactly at the limit.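

For the compounds shown here, compound 3 and compound 4 both stand only as limits, so no step between them can be read in this assay. The compounds shown leave open whether any of them has a measurable half-maximal effective concentration here: the limit of > 36600 nM in this assay, at which 4 of the 4 values shown sit.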